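A few compounds are considered here, and "the series" means these few. Any claim that something is new, unique, unknown or untested is made for them only; others in the source may bear on it.

Measured compounds:
Compound 1 `CCn1cc(-c2nc3ccccc3o2)c(=O)c2cc(F)c(N3CCNC(C)C3)c(F)c21` gives 83500 nM in a functional assay on A2780 cells (Homo sapiens) for cytotoxicity, read by MTT assay, with a stated time of 48 h; on this read-out lower numbers stand for stronger inhibition and higher numbers for weaker inhibition.
Compound 2 `CCn1cc(-c2nc3ccccc3s2)c(=O)c2cc(F)c(N3CCNCC3)nc21` gives 2700 nM in this assay.
Compound 3 `CCn1cc(-c2nc3ccc([N+](=O)[O-])cc3o2)c(=O)c2cc(F)c(N3CCNC(C)C3)c(F)c21` gives 200 nM in this assay.

Compound 3 differs from compound 1 by one change, (nitro in place of hydrogen on an aromatic carbon), and that change brought a large step, a 420-fold lower number from compound 1 to compound 3 (2.62 log units; beyond the scatter). Compound 2 carries a different core; the difference between the two cores is not broken down here. Compound 4 `CCn1cc(-c2nc3ccc([N+](=O)[O-])cc3s2)c(=O)c2cc(F)c(N3CCNCC3)nc21` repeats the same change on the core of compound 2, (nitro in place of hydrogen on an aromatic carbon), at a place described in the same words. Because the earlier step of a 420-fold lower number from compound 1 to compound 3 (2.62 log units; beyond the scatter) was so large, compound 4 is expected to sit well below compound 2 in this assay, though the different core gives no assurance of an equal size, so the expected step is an 18-fold lower number from compound 2 to compound 4 (1.26 log units; beyond the scatter). Compound 4 is estimated at 150 nM, between 20 nM and 1200 nM.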

Compound 4, half-maximal inhibitory concentration: 200000 nM
The estimate for compound 4 lay 1300-fold (3.12 log units) below the measured number; the whole stated range lies below it.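

In this assay, nitro in place of hydrogen on an aromatic carbon gave a 74-fold higher number from compound 2 to compound 4 (1.87 log units; beyond the scatter), which runs in the opposite direction to the step on the core of compound 1. In this series, then, the effect of this change did not carry from one core to the other, in either direction or size: the same change on two cores in this assay, a 420-fold lower number (2.62 log units; beyond the scatter) from compound 1 to compound 3 and a 74-fold higher number (1.87 log units; beyond the scatter) from compound 2 to compound 4, 31000-fold (4.49 log units) apart, beyond the scatter of two such steps. Among these compounds, these two steps do not show which of the differences between the cores lies behind the reversal, and each core offers only one example.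

Going by these compounds, it remains open how an amine or a carboxylic acid in place of that hydrogen would behave on each core. On these data alone, it also remains open whether either group would show the same split between the two cores.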